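The compounds below may be only part of what the source reports. "The series", "measured", "known", "first", "only" and "open" are said of these compounds alone.

In a functional assay on HeLa cells (Homo sapiens) for inhibition (on this read-out higher numbers stand for weaker inhibition and lower numbers for stronger inhibition), compound 1 (`CCN(C(=O)CC(CC(=O)NCCN1CCCC1)c1ccc(Cl)cc1)C1Cc2ccccc2C1`) gives 36400 nM and compound 2 (`CCNCCNC(=O)CC(CC(=O)N(CC)C1Cc2ccccc2C1)c1ccc(Cl)cc1`) gives 40500 nM so the two stand level. Compound 3 (`CCNCCNC(=O)CC(CC(=O)N(CC)C1Cc2ccccc2C1)c1ccccc1`) carries hydrogen in place of chloro on an aromatic carbon and is still unmeasured. Going by the values given here, the only measured step (a 1.1-fold higher number from compound 1 to compound 2 (0.05 log units; within the scatter)) swaps pyrrolidin-1-yl for ethylamino on the chain, so no measured step touches the aromatic ring, and no change beyond the scatter is expected. The expected step (a 1.2-fold higher number from compound 2 to compound 3 (0.09 log units; within the scatter)) is small. Compound 3 is estimated at 50000 nM (range 25000 nM to 100000 nM) in this series.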

Compound 3, half-maximal inhibitory concentration: > 100000 nM
Compound 3: no number, only a limit; the forecaster's own chance of this, stated with the estimate: 20%; at least 2.0-fold (0.30 log units) between middle value and limit.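

Going from 4-chlorophenyl to phenyl gives an at least 2.4-fold higher number from compound 2 to compound 3 (0.39 log units; beyond the scatter), the first step in this series beyond the scatter in this assay, so this place on the aromatic ring counts for more than the chain end did. Compound 3 stands at > 100000 nM, a limit of the assay and not a number. The full size of the step stays unknown because of that limit: the limit of > 100000 nM in this assay, at which 1 of the 3 values shown sits.

Open, from the compounds shown here alone, is whether bromo, methyl or trifluoromethyl on this aromatic carbon would serve as chloro does. Also open, going by these compounds, is whether losing chloro costs the same with pyrrolidin-1-yl at the chain end.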